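The compounds below may be only part of what the source reports. "The series", "measured", "known", "first", "only" and "open" are said of these compounds alone.

In a functional assay on MDA-MB-231 cells (Homo sapiens) for cytotoxicity, read by MTT assay, with a stated time of 72 h (a lower number here means a stronger inhibitor, a higher number a weaker inhibitor), compound 1 (`O=C1c2c[n+]([O-])c3ccccc3c2C(=O)c2c1c1ccccc1n2CCN1CCCC1`) gives 630 nM, compound 2 (`CC1(C)O[C@@H](CO)[C@H](Cn2cc(Cn3c4c(c5ccccc53)C(=O)c3c[n+]([O-])c5ccccc5c3C4=O)nn2)O1`) gives 680 nM and compound 3 (`CC1(C)OC[C@H](Cn2cc(Cn3c4c(c5ccccc53)C(=O)c3c[n+]([O-])c5ccccc5c3C4=O)nn2)O1`) gives 530 nM. These three numbers lie within the scatter of one another, so compound 1 stands level with the other two. Compound 4 (`CN(C)CCCCn1c2c(c3ccccc31)C(=O)c1c[n+]([O-])c3ccccc3c1C2=O`) departs from compound 1 as follows: 2-(dimethylamino)ethyl in place of pyrrolidin-1-yl on a saturated chain carbon, two bonds along the chain from an aromatic nitrogen. In words, 2-(dimethylamino)ethyl replaces pyrrolidin-1-yl on a saturated chain carbon, two bonds along the chain from an aromatic nitrogen. For the measured compounds named here, no measured step covers this exchange. The only one available, a 1.3-fold lower number from compound 2 to compound 3 (0.11 log units; within the scatter), is a different change, hydrogen in place of hydroxymethyl on a saturated ring carbon, and it stays small. The expected step in this assay, a 1.1-fold lower number from compound 1 to compound 4 (0.04 log units; within the scatter), is therefore none beyond the scatter. Compound 4 is estimated at 580 nM, with an expected range from 250 nM to 1300 nM.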

Compound 4, half-maximal inhibitory concentration: 350 nM
For compound 4 the middle estimate is 1.7-fold (0.22 log units) above the measured one; low and high end bracket the measured number.
By their numbers in this assay, from the lowest: compounds 4, 3, 1 and 2 (each within the scatter of the next).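

With the ring of compound 1 gone and 2-(dimethylamino)ethyl in place of pyrrolidin-1-yl, this assay gives a 1.8-fold lower number from compound 1 to compound 4 (0.26 log units; within the scatter). On this saturated chain carbon, two bonds along the chain from an aromatic nitrogen, the ring can therefore be exchanged for an open chain with the same count of heavy atoms, and the number stays within the scatter. Nothing shown here explains this result. The compounds shown leave open whether a carboxylic acid or a morpholin-4-yl group at this place would also stay within the scatter, and what a longer chain would do.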